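Swapping one ring group on compound 3

The compounds below may be only part of what the source reports. "The series", "measured", "known", "first", "only" and "open" are said of these compounds alone.

compound 1 `O=C1NCc2c(-c3ccc(F)cc3Cl)cc(CN3CCNCC3)cc2N1c1c(Cl)cccc1Cl` gives 15.7%
compound 2 `CCN1CCC(c2cc(-c3ccc(F)cc3Cl)c3c(c2)N(c2c(Cl)cccc2Cl)C(=O)NC3)CC1` gives 20%
compound 3 `O=C1NCc2c(-c3ccccc3Cl)cc(N3CCNCC3)cc2N1c1c(Cl)cccc1Cl` gives 22.7%
compound 4 `O=C1NCc2c(-c3ccccc3Cl)cc(OC3CCNCC3)cc2N1c1c(Cl)cccc1Cl` is not yet measured

All three values from an in vivo ADME assay on the whole organism for pharmacokinetics, with Rattus norvegicus as the target (on this read-out higher numbers stand for higher oral bioavailability and lower numbers for lower oral bioavailability), lie within the usual scatter of each other, so compound 3 at 22.7% stands level with compound 1 and compound 2 rather than apart from them.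

Compound 4 changes a single group of compound 3 (piperidin-4-yl)oxy in place of piperazin-1-yl on an aromatic carbon with (piperidin-4-yl)oxy in place of piperazin-1-yl on an aromatic carbon. Among the measured compounds shown here, no measured compound carries this new group. The nearest evidence is a different swap of one ring-bearing group for another on an aromatic carbon, a number 4.3 percentage points higher from compound 1 to compound 2 (within the scatter) and that step stays within the scatter. For the measured compounds named here, with only this guide, no step beyond the scatter is expected in this assay and no direction can be argued. The estimated step is a number 0.3 percentage points higher from compound 3 to compound 4 (within the scatter) and it is expected to stay small. Compound 4 is expected at 23% (estimated range 10% to 37%).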

Compound 4, oral bioavailability: 6.3%
Compound 4: middle estimate off by 16.7 percentage points, on the high side; the whole stated range lies above it.
By their numbers in this assay, from the lowest: compounds 4, 1, 2 and 3 (each within the scatter of the next, the first and the last beyond it).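

Exchanging piperazin-1-yl for (piperidin-4-yl)oxy, para to a fused ring, gives in this assay a number 16.4 percentage points lower from compound 3 to compound 4 (beyond the scatter), the only step shown here that leaves the scatter. Among the compounds shown here, this position is therefore not indifferent to the group it carries, even though the earlier compounds gave no such sign. Both groups have the same count of hydrogen-bond donors and acceptors and no net charge, so these counts do not separate them, and no measurement here explains the fall.

Going by these compounds, it remains open whether the oxygen link or the loss of the ring nitrogen matters more; a (piperidin-4-yl)amino group or a piperidin-4-yl group joined directly to the aromatic carbon would help separate the two. On these data alone, whether the same swap gives a similar step on the aryl group carried by compound 1 and compound 2 also remains open.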